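Swapping the Sulfonamide Nitrogen Substituent: Expected Lipophilicity

A few compounds are considered here, and "the series" means these few. Any claim that something is new, unique, unknown or untested is made for them only; others in the source may bear on it.

Compound 1 `CCc1ccc(N(CC(C)C)S(=O)(=O)c2ccc3c(c2)C(=O)CC(CC2CCOCC2)O3)cc1`: 4.53
Compound 2 `CC(C)CN(Cc1ccccc1C(F)(F)F)S(=O)(=O)c1ccc2c(c1)C(=O)CC(C1CCOCC1)O2`: 4.32

In a physicochemical assay for lipophilicity, at pH 7.4 (a higher number here means a more lipophilic compound, a lower number a more polar compound), compound 2 gives 4.32, the lowest of the two numbers, while compound 1 gives 4.53; the gap between them lies within the scatter, so the two cannot be ranked against each other. Compound 3 `CC(C)CN(c1cccc(F)c1)S(=O)(=O)c1ccc2c(c1)C(=O)CC(C1CCOCC1)O2` differs from compound 2 by 3-fluorophenyl in place of 2-(trifluoromethyl)benzyl on a sulfonamide nitrogen. Going by the values given here, no measured pair shows this change, so the expectation rests on the structures alone. In this assay a drop beyond the scatter is expected, amounting to an estimated step of a number 0.92 log units lower from compound 2 to compound 3 (beyond the scatter). Compound 3 is therefore expected to come out near 3.4, within a range from 2.9 to 3.9.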

Compound 3, distribution coefficient: 3.5
The estimate for compound 3 lay 0.10 log units below the measured number; low and high end bracket the measured number.
By their numbers in this assay, from the lowest: compound 3; then compounds 2 and 1 (each within the scatter of the next).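

In this assay, going by these compounds alone, the swap of 2-(trifluoromethyl)benzyl for 3-fluorophenyl on a sulfonamide nitrogen gives a number 0.82 log units lower from compound 2 to compound 3 (beyond the scatter) and provides the first readable step at this position. It shows that changing this one substituent, with the rest of the molecule held constant, can move the number beyond the scatter. Nothing measured here explains the step.

On these data alone, because the two groups differ in several ways at once, the part of the swap that matters remains open. So does the outcome of placing an amine or a carboxylic acid on this nitrogen.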